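The source may report more compounds than this note shows. Statements on the series, on what has been measured and on what is new or still open speak of the compounds shown alone.

In a functional assay on A549 cells (Homo sapiens) for cytotoxicity, read by MTT assay, with a stated time of 48 h (on this read-out higher numbers stand for weaker inhibition and lower numbers for stronger inhibition), the three measured compounds gave the following numbers:

- compound 1 `CCCCCCCC1C(CO[C@@H]2O[C@@H]3CO[C@H](c4ccccc4)O[C@@H]3[C@H](OCc3ccccc3)[C@H]2O)N1S(=O)(=O)c1ccc(C)cc1`: 235000 nM
- compound 2 `CCCC1(CO[C@@H]2O[C@@H]3CO[C@H](c4ccccc4)O[C@@H]3[C@H](OCc3ccccc3)[C@H]2OCc2ccccc2)CN1S(=O)(=O)c1ccc(C)cc1`: 579000 nM
- compound 3 `Cc1ccc(S(=O)(=O)N2C(C)C2CO[C@@H]2O[C@@H]3CO[C@H](c4ccccc4)O[C@@H]3[C@H](OCc3ccccc3)[C@H]2OCc2ccccc2)cc1`: 804000 nM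

Compound 3 has the highest number of the three. Compound 2 stands nearest to it and the two values lie within the usual scatter of the measurement, so no order between them can be claimed. Compound 1 stands furthest away with a lower number, and that gap is beyond the scatter.

Compound 4 `Cc1ccc(S(=O)(=O)N2CC2CO[C@@H]2O[C@@H]3CO[C@H](c4ccccc4)O[C@@H]3[C@H](OCc3ccccc3)[C@H]2OCc2ccccc2)cc1` is not yet measured. It differs from compound 3 in one place: hydrogen in place of methyl on a saturated ring carbon. Among the measured compounds shown here, no step between two measured compounds shows what this change does, so nothing more than the size of the change itself can be drawn on. A single carbon leaving from a compound that already sits at very weak inhibition gives little reason to expect a move beyond the scatter in either direction. For compound 4 in this assay the estimate is 700000 nM, with a range from 300000 nM to 1600000 nM. This estimate means a step of a 1.1-fold lower number from compound 3 to compound 4 (0.06 log units; within the scatter) that is expected to stay within the scatter.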

Compound 4, half-maximal inhibitory concentration: 73000 nM
Estimate against measurement, compound 4: 9.6-fold (0.98 log units) above; the whole stated range lies above it.
By their numbers in this assay, from the lowest: compound 4; then compound 1; then compounds 2 and 3 (each within the scatter of the next).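

In this assay a single carbon on this small ring proves to matter far more than its size suggested: hydrogen in place of methyl on a saturated ring carbon gives an 11-fold lower number from compound 3 to compound 4 (1.04 log units; beyond the scatter). Hydrogen in place of propyl on a saturated ring carbon points the same way, with a 7.9-fold lower number from compound 2 to compound 4 (0.90 log units; beyond the scatter), so among these three compounds the ring without a carbon substituent gives the lowest number, although the methyl and the propyl do not stand on the same ring carbon. Nothing measured here explains why the loss of either group has this effect.

Going by these compounds, it remains open whether only a bare ring carbon gives this low number, or whether a smaller change, such as a hydroxymethyl or an amine on that carbon, could keep it. It is also unknown whether the same step would appear with a different group on the ring nitrogen, such as a benzoyl group.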